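Methoxy scan on the cinnamoyl phenol series: para position

The source may hold more compounds than are shown below. What is called first, only, known or untested is meant among the compounds shown, and "the series" means these compounds.

Compound 1 `CC(=O)Nc1ccc(O)c(C(=O)/C=C/c2ccccc2)c1` is the parent of this set. For the measured compounds named here, in an ADME assay on THP-1 cells (Homo sapiens) for cytotoxicity, read by flow cytometry and propidium iodide staining, with a stated time of 72 h (a higher number here means a weaker inhibitor, a lower number a stronger inhibitor), compound 1 gives 85500 nM, one of only two numbers measured, and its steps to the other compounds are summarised below. Compound 3 `COc1cccc(/C=C/C(=O)c2cc(NC(C)=O)ccc2O)c1` gives 93700 nM in this assay, a value within the scatter of compound 1. Compound 2 `COc1ccccc1/C=C/C(=O)c1cc(NC(C)=O)ccc1O` gives > 125000 nM in this assay, which is a limit and not a number. Compound 4 `COc1ccc(/C=C/C(=O)c2cc(NC(C)=O)ccc2O)cc1` differs from compound 1 by methoxy in place of hydrogen on an aromatic carbon. Going by the values given here, the steps that bear on it are both methoxy in place of hydrogen on an aromatic carbon: an at least 1.4-fold higher number from compound 1 to compound 2 (0.16 log units; that floor lies within the scatter) and a 1.1-fold higher number from compound 1 to compound 3 (0.04 log units; within the scatter). Neither moves beyond the scatter, and one of the three values sits at the limit of > 125000 nM in this assay, at which 1 of the 3 values shown sits. Compound 4 is therefore expected to show no step beyond the scatter, at most a small rise, a 1.1-fold higher number from compound 1 to compound 4 (0.05 log units; within the scatter). Compound 4 is estimated at 95000 nM with a range of 60000 nM to 150000 nM.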

Compound 4, half-maximal inhibitory concentration: 59200 nM
Compound 4: the middle estimate sits 1.6-fold (0.21 log units) above what was measured; measured number outside the range, below it.
By their numbers in this assay, from the lowest: compounds 4, 1 and 3 (each within the scatter of the next). At a limit, above all of these: compound 2.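

Placing methoxy on the aromatic carbon para to a large group gives a 1.4-fold lower number from compound 1 to compound 4 (0.16 log units; within the scatter) in this assay, so this position also shows no readable effect of the change, and the direction of the step carries no weight. With compound 4, the steps from compound 1 that can be read as numbers now include two placements of methoxy, and neither leaves the scatter, so compound 1 and compound 4 cannot be ordered in this assay. The series still holds one value that is not a number: the limit of > 125000 nM in this assay, at which 1 of the 4 values shown sits.

From the compounds shown here alone, it remains open whether an amine or a carboxylic acid on this same aromatic carbon would give a step beyond the scatter. A longer chain such as ethoxy or butoxy in place of methoxy, and methoxy on more than one carbon of this ring, are equally unresolved.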